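A Chloro-to-Hydrogen Step Carried from One Core to Another

The source may report more compounds than this note shows. Statements on the series, on what has been measured and on what is new or still open speak of the compounds shown alone.

Measured in a functional assay on U-87MG ATCC cells for antiproliferative activity against U-87 MG (Homo sapiens), read by MTT assay, with a stated time of 48 h, tested at 100 uM; a lower number here means a stronger effect, a higher number a weaker effect of the compound at the concentration tested:
compound 1 `COc1ccc(-c2nc(C)c(C(=O)CSc3nc(N)c(C#N)c(-c4ccc(Cl)cc4)n3)s2)cc1` gives 3.9%
compound 2 `COc1ccc(-c2nc(C)c(C(=O)CSc3nc(N)c(C#N)c(-c4ccccc4)n3)s2)cc1` gives 5.25%
compound 3 `Cc1nc(-c2ccccc2)sc1C(=O)CSc1nc(-c2cccc(Cl)c2)c(C#N)c(=O)[nH]1` gives 10%

Compound 1 and compound 2 share one core and differ by hydrogen in place of chloro on an aromatic carbon. That change made a number 1.4 percentage points higher from compound 1 to compound 2 (within the scatter). Compound 3 carries a different core; how its core differs from that of compound 1 is not broken down here. The values of compound 3 and compound 2, and those of compound 3 and compound 1, are all within the usual scatter of each other, so no order among the three can be read from them.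

Compound 4 `Cc1nc(-c2ccccc2)sc1C(=O)CSc1nc(-c2ccccc2)c(C#N)c(=O)[nH]1` differs from compound 3 by hydrogen in place of chloro on an aromatic carbon. This is the same kind of change as that from compound 1 to compound 2, but not the same: there the chloro sat para to a large group, here it sits meta to a large group.

For compound 4 a step of about a number 1.5 percentage points higher from compound 3 to compound 4 (within the scatter) is expected in this assay, beside the earlier one, because a number 1.4 percentage points higher from compound 1 to compound 2 (within the scatter) was within the scatter and the difference in the place of the chloro gives no reason to expect more. Compound 4 is therefore estimated at 11.5%, with a range from 3% to 25%.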

Compound 4, a percentage reported as activity, at one concentration (the size of the read-out at that concentration, not a potency): 9.23%
Estimate against measurement, compound 4: 2.3 percentage points above; the measured number falls inside the stated range.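

Replacing chloro with hydrogen on the core of compound 3 gave a number 0.8 percentage points lower from compound 3 to compound 4 (within the scatter) in this assay. Set beside the earlier step, the change shows no difference between the two cores that this read-out can resolve: the same change on two cores in this assay, a number 1.4 percentage points higher (within the scatter) from compound 1 to compound 2 and a number 0.8 percentage points lower (within the scatter) from compound 3 to compound 4, 2.1 percentage points apart, within the scatter of two such steps. This shows that the change carried from one core to the other without a step beyond the scatter on either, but it does not show that the chloro is without effect or that the two steps are equal, and the read-out, taken at one concentration, is not a potency.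

The compounds shown leave open whether a bromo or trifluoromethyl group, an amine or a carboxylic acid in the place of the chloro would move the number beyond the scatter. They also leave open how the change would read on the two cores with the chloro in the same place on both, as its place differs between the two pairs.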